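Swapping the Fluorophenyl on the Cyclopropane for a Methylthiazole

This account rests on a few compounds, and the source may have more. Where it says the series, first, only, none or still open, it means among the compounds named here.

Of the compounds shown here, three have been measured in a functional assay for agonist activity at G protein-coupled receptor 88 (Homo sapiens), read by HTRF and cAMP accumulation; on this read-out lower numbers stand for an effect already at smaller amounts and higher numbers for an effect only at larger amounts of compound. Compound 1 `NC1(CN(C(=O)[C@@H]2C[C@H]2c2ccccc2)c2ccc(-c3ccccc3)cc2)CCCC1` gives 0.57 nM. Going by the values given here, compound 2 `CC(C)(C)[C@H](N)CN(C(=O)[C@@H]1C[C@H]1c1ccccc1)c1ccc(-c2ccccc2)cc1` gives 11 nM; the step of a 19-fold higher number from compound 1 to compound 2 (1.29 log units; beyond the scatter) is the only single-point change measured so far, and it concerns the amine-bearing chain rather than the aryl group on the cyclopropane. Compound 3 `CC[C@H](C)[C@H](N)CN(C(=O)[C@@H]1C[C@H]1c1cccc(F)c1)c1ccc(-c2ccccc2)cc1` gives 560 nM, the highest of the three numbers and beyond the scatter from both compound 1 and compound 2. Compound 3 and compound 2 differ in two places at once, so their values show only the combined effect of the chain and the fluorine on the phenyl ring.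

Compound 4 `CC[C@H](C)[C@H](N)CN(C(=O)[C@@H]1C[C@H]1c1ncc(C)s1)c1ccc(-c2ccccc2)cc1` differs from compound 3 in one place: 5-methyl-1,3-thiazol-2-yl in place of 3-fluorophenyl on a saturated ring carbon. Among the compounds with values here, no measured step touches the aryl group on the saturated ring carbon of the three-membered ring, so nothing among the measured compounds tells how this assay responds to such a change. He therefore expects no step beyond the scatter, with a wide range to reflect the missing precedent, that is a 1.1-fold lower number from compound 3 to compound 4 (0.05 log units; within the scatter). For compound 4 he estimates 500 nM, between 100 nM and 3000 nM.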

Compound 4, half-maximal effective concentration: 1300 nM
The estimate for compound 4 lay 2.6-fold (0.41 log units) below the measured number; low and high end bracket the measured number.
By their numbers in this assay, from the lowest: compound 1; then compound 2; then compound 3; then compound 4.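

Going by these compounds alone, this is the first measured step at the aryl group on a saturated ring carbon of the three-membered ring, and in this assay it reads a 2.3-fold higher number from compound 3 to compound 4 (0.37 log units; beyond the scatter) and so lies beyond the scatter. The position therefore responds to this exchange, but the step is modest beside the one printed for the amine-bearing chain, a 19-fold higher number from compound 1 to compound 2 (1.29 log units; beyond the scatter) on a different pair, and 5-methyl-1,3-thiazol-2-yl, a five-membered aromatic ring with 2 hetero atoms and 2 hydrogen-bond acceptors, still leaves compound 4 with a measurable value of 1300 nM in place of the six-membered aromatic ring of carbon only in 3-fluorophenyl. Nothing at hand accounts for the direction or size of this step.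

From the compounds shown here alone, the aryl position rests on this single pair, so it remains open whether the same exchange would give a similar step on the 1-aminocyclopentyl chain of compound 1, which has the lowest number of the series. Going by these compounds, it also remains open whether the methyl group matters, which an unsubstituted 1,3-thiazol-2-yl or a pyridin-2-yl group at this place could address.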